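A rigid pyrrolidine replaces the flexible urea chain

The source may hold more compounds than are shown below. What is called first, only, known or untested is meant among the compounds shown, and "the series" means these compounds.

Compound 2 `CCNC(=O)NCCCc1cccc2oc(CCCCc3ccccc3)cc12` is the compound with the lowest number of the two measured here. In an assay on NIH3T3 cells for binding affinity to melatonin receptor type 1B (Homo sapiens) (a lower number here means a stronger inhibitor, a higher number a weaker inhibitor), compound 2 gives 52 nM; compound 1 `CC(C)C(=O)NCCCc1cccc2oc(CCCCc3ccccc3)cc12` gives 83 nM. Among the compounds with values here, the only measured step, a 1.6-fold lower number from compound 1 to compound 2 (0.20 log units; within the scatter), concerns the group on the carbonyl carbon and lies within the scatter, so the two compounds cannot be ordered.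

Compound 3 `CC(=O)N[C@H]1CCN(c2cccc3oc(CCCCc4ccccc4)cc23)C1` departs from compound 2 in a different way: 3-acetamidopyrrolidin-1-yl in place of 3-((ethylcarbamoyl)amino)propyl on an aromatic carbon, on an aromatic carbon of a six-membered aromatic ring of carbon only, part of a fused system of two rings. Within the data shown here, the change swaps an open chain for a five-membered ring attached through its nitrogen, and no measured step touches this part of the molecule; the step from compound 1 to compound 2 tells nothing about it. The expectation therefore rests on compound 2 alone, and the step of a 1.9-fold higher number from compound 2 to compound 3 (0.28 log units; within the scatter) is estimated only loosely, with no direction claimed beyond the scatter. For compound 3 a value of 100 nM is estimated in this assay, within a wide range from 20 nM to 600 nM.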

Compound 3, inhibition constant: 14 nM
For compound 3 the middle estimate is 7.1-fold (0.85 log units) above the measured one, and the stated range ends above it.
By their numbers in this assay, from the lowest: compound 3; then compounds 2 and 1 (each within the scatter of the next).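

Within the data shown here, at the aromatic carbon that carries the side chain, this is the first change in the set that moves the number beyond the scatter: in this assay the swap to 3-acetamidopyrrolidin-1-yl gives a 3.7-fold lower number from compound 2 to compound 3 (0.57 log units; beyond the scatter) and, against the isopropyl amide, a 5.9-fold lower number from compound 1 to compound 3 (0.77 log units; beyond the scatter). Compound 3 therefore stands apart from compounds 1 and 2, and at this position replacing the open chain with the ring reaches a number that the change on the carbonyl carbon did not separate, even though the entering and leaving groups in the step from compound 2 hold the same number of heavy atoms. No measurement available here explains this difference.

The change alters several features at once, namely the ring, the attachment through nitrogen, the amide in place of the urea and the defined stereocentre, so the compounds shown do not reveal which of these accounts for the step. Also open, as far as these compounds go, is how the number would respond to the opposite configuration at the stereocentre, an ethyl urea on the same pyrrolidine, a six-membered piperidine ring or a free amine in place of the acetamide.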